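Curcuminoid-terpene conjugates: side-chain ketone step

The compounds below may be only part of what the source reports. "The series", "measured", "known", "first", "only" and "open" are said of these compounds alone.

Within the data shown here, compound 1 `COc1cc(/C=C/C(=O)/C=C(O)/C=C/c2ccc(O[C@H]3C=C(C)[C@@H](O)C[C@@H]3[C@@H](C)CCC=C(C)C)c(OC)c2)ccc1O` gives 30600 nM in a functional assay on A549 cells (Homo sapiens) for cytotoxicity, read by crystal violet staining, with a stated time of 72 h (on this read-out higher numbers stand for weaker inhibition and lower numbers for stronger inhibition), the second highest of the three numbers measured so far. Compound 2 `COc1cc(/C=C/C(=O)/C=C(O)/C=C/c2ccc(O[C@H]3C[C@H]([C@@H](C)CC(=O)C=C(C)C)C=C[C@@]3(C)O)c(OC)c2)ccc1O` gives 14300 nM in this assay, a lower number than compound 1 by a gap beyond the usual scatter. Compound 3 `COc1cc(/C=C/C(=O)/C=C(O)/C=C/c2cc(OC)c(O)c([C@H]3C=C(C)[C@@H](O)C[C@@H]3[C@@H](C)CCC=C(C)C)c2)ccc1O` gives 84300 nM in this assay, a higher number than compound 1, again beyond the scatter. Compound 4 `COc1cc(/C=C/C(=O)/C=C(O)/C=C/c2ccc(O[C@H]3C=C(C)[C@@H](O)C[C@@H]3[C@@H](C)CC(=O)C=C(C)C)c(OC)c2)ccc1O` is not yet measured. It differs from compound 1 in one place: (2-methylprop-1-en-1-yl)carbonyl in place of 3-methylbut-2-en-1-yl on a saturated chain carbon, two bonds along the chain from a saturated ring carbon. Among the measured compounds shown here, no step between measured compounds isolates this change. Compound 2 also bears a carbonyl but differs from compound 1 in further places as well, so the number of compound 2, 14300 nM, is only a loose pointer. The estimated step is a 1.6-fold lower number from compound 1 to compound 4 (0.21 log units; within the scatter), a modest lowering that may not clear the scatter. Compound 4 is expected to give 19000 nM, within 8000 nM to 45000 nM.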

Compound 4, half-maximal inhibitory concentration: 16100 nM
For compound 4 the middle estimate is 1.2-fold (0.07 log units) above the measured one; the range from low to high includes it.
By their numbers in this assay, from the lowest: compounds 2, 4 and 1 (each within the scatter of the next, the first and the last beyond it); then compound 3.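

In this assay, (2-methylprop-1-en-1-yl)carbonyl in place of 3-methylbut-2-en-1-yl at this chain position can now be read on its own: a 1.9-fold lower number from compound 1 to compound 4 (0.28 log units; within the scatter). The position thus accepts the added carbonyl, with its hydrogen-bond acceptor, without a step beyond the scatter. Nothing at hand accounts for the size of this step.

Going by these compounds, whether an amine, a carboxylic acid or a longer chain at this position would give a step beyond the scatter remains open.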